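Bromo for Chloro on an Adenosine Receptor Ligand

The source may hold more compounds than are shown below. What is called first, only, known or untested is meant among the compounds shown, and "the series" means these compounds.

Compound 1, `C=CCn1c(=O)c2[nH]c(-c3ccccc3)nc2n(C)c1=O`, gives 4 nM in an assay for binding affinity to adenosine receptor A1 (Bos taurus); a higher number here means a weaker inhibitor, a lower number a stronger inhibitor.
Compound 2, `Cn1c(=O)c2nc(-c3ccc(Cl)cc3)[nH]c2n(C)c1=O`, gives 0.8 nM in this assay.

Among these two measured compounds, compound 2 has the lowest number, meaning the stronger inhibition; compound 1 lies at a higher number, and that gap is beyond the usual scatter of repeated measurements. Compound 1 and compound 2 differ in more than one place, so their two values are simply shown side by side here, without a single change to point to.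

The next compound, compound 3, `Cn1c(=O)c2nc(-c3ccc(Br)cc3)[nH]c2n(C)c1=O`, is not yet measured. It differs from compound 2 in one place only: bromo in place of chloro on an aromatic carbon. Among the compounds with values here, exchanging one halogen for another of the same kind on the same position is a small alteration, and with no measured pair in this set showing what such a swap does, the expectation rests on the size of the change alone. A step from compound 2 to compound 3 of about a 1.1-fold lower number from compound 2 to compound 3 (0.06 log units; within the scatter) in this assay is expected, that is, no change beyond the scatter. Compound 3 is therefore estimated at 0.7 nM, with a likely range from 0.3 nM to 1.6 nM.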

Compound 3, half-maximal inhibitory concentration: 0.75 nM
For compound 3 the middle estimate is 1.1-fold (0.03 log units) below the measured one; the measured number falls inside the stated range.
By their numbers in this assay, from the lowest: compounds 3 and 2 (each within the scatter of the next); then compound 1.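

Within the data shown here, the first pair in this set that differs in one place shows a 1.1-fold lower number from compound 2 to compound 3 (0.03 log units; within the scatter) in this assay. At this aromatic carbon, para to a large group, bromo and chloro therefore cannot be told apart by this measurement, and one halogen can stand in for the other without a change beyond the scatter. Compound 1 and compound 2 could not show this, since they differ in more than one place, and nothing measured here explains why the two halogens give such similar results.

The compounds shown leave open whether this position accepts anything other than a halogen, such as a methoxy group, an amine or a carboxylic acid, and a bare hydrogen there appears only in compound 1, which also carries other differences. Going by these compounds, it also remains open whether the same exchange would give so small a step on another carbon of that ring, or on a version of the core bearing the allyl group of compound 1 or a longer chain.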